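Acetyl for Hydrogen: Predicting the Cytotoxicity of Compound 4

The compounds below may be only part of what the source reports. "The series", "measured", "known", "first", "only" and "open" are said of these compounds alone.

Of the compounds shown here, three of this set have been tested in a functional assay on Lu1 cells (Homo sapiens) for cytotoxicity, read by sulforhodamine B assay; on this read-out lower numbers stand for an effect already at smaller amounts and higher numbers for an effect only at larger amounts of compound. Compound 1 `C=C1CC[C@@H]2[C@](C)(CO[Si](c3ccccc3)(c3ccccc3)C(C)(C)C)[C@H](OC(C)=O)CC[C@@]2(C)[C@@H]1C/C=C1/C(=O)OC[C@H]1O` gives 10.9 uM in this assay. Compound 2 `C=C1CC[C@@H]2[C@](C)(CO[Si](C)(C)C(C)(C)C)[C@H](OC(C)=O)CC[C@@]2(C)[C@@H]1C/C=C1/C(=O)OC[C@H]1OC(C)=O` gives 2.92 uM, and compound 3 `C=C1CC[C@@H]2[C@](C)(CO[Si](C)(C)C(C)(C)C)[C@H](O)CC[C@@]2(C)[C@@H]1C/C=C1/C(=O)OC[C@H]1OC(C)=O` gives 10.4 uM. Compound 1 and compound 3 differ in more than one place, and the difference between the two cores is not broken down here; their numbers in this assay lie within the scatter of each other, so nothing can be said about an order between them. Compound 2 and compound 3 differ in one place only, by acetyl in place of hydrogen on an oxygen on a saturated carbon, and this change brought a 3.6-fold lower number from compound 3 to compound 2 (0.55 log units; beyond the scatter), a modest step that lies beyond the scatter.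

The same change, (acetyl in place of hydrogen on an oxygen on a saturated carbon), turns compound 1 into compound 4 `C=C1CC[C@@H]2[C@](C)(CO[Si](c3ccccc3)(c3ccccc3)C(C)(C)C)[C@H](OC(C)=O)CC[C@@]2(C)[C@@H]1C/C=C1/C(=O)OC[C@H]1OC(C)=O`, which has not yet been measured. Among the compounds here the change occurs twice in all, and only once with a number on both sides. The expectation for compound 4 rests on that single example: compound 1 sits at 10.9 uM, and the step seen as a 3.6-fold lower number from compound 3 to compound 2 (0.55 log units; beyond the scatter) is taken as the guide for the new pair. On this basis compound 4 is expected to show a 3.6-fold lower number from compound 1 to compound 4 (0.56 log units; beyond the scatter) in this assay. Compound 4 is therefore estimated at about 3 uM, with the value expected to fall between 1.4 uM and 8 uM.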

Compound 4, concentration for half-maximal effect: 52.9 uM
For compound 4 the middle estimate is 18-fold (1.25 log units) below the measured one, outside the stated range (above it).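

In this assay, hydroxy to acetoxy on the core of compound 1 brought a 4.9-fold higher number from compound 1 to compound 4 (0.69 log units; beyond the scatter), so the earlier step did not carry over in either size or direction, and the two steps stand clearly apart: the same change on two cores in this assay, a 3.6-fold lower number (0.55 log units; beyond the scatter) from compound 3 to compound 2 and a 4.9-fold higher number (0.69 log units; beyond the scatter) from compound 1 to compound 4, 17-fold (1.24 log units) apart, beyond the scatter of two such steps

This shows that, among these compounds, the effect of adding an acetyl on one core gives no safe guide to its effect on another, and that a single pair is too thin a basis for such a transfer. It does not show what reverses the step: the two pairs differ in the silyl group they carry, and the acetyl enters at a different oxygen in each pair, so these two differences cannot be separated here, and two pairs establish no general rule for the series.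

What the compounds shown leave open is whether a longer acyl chain, such as propionyl, or a benzoyl group on the same oxygen would follow the step seen from compound 1 to compound 4. Going by these compounds, it also remains open how a carbamate or an ether at each of the two oxygens would read on either core, which might show whether the outcome depends on the oxygen or on the silyl group.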